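The source may report more compounds than this note shows. Statements on the series, on what has been measured and on what is new or still open speak of the compounds shown alone.

In a functional assay on A549 cells (Homo sapiens) for inhibition, read by CCK-8 assay, with a stated time of 72 h, tested at 2 uM (on this read-out lower numbers stand for less inhibition of growth and higher numbers for more inhibition of growth at the one concentration tested), compound 1 (`Cc1ccc(SCc2ccc(/C=C/C(=O)Nc3ccccc3N)cc2)cc1`) gives 43.4%, compound 2 (`Nc1ccccc1NC(=O)/C=C/c1ccc(CSc2ccc(F)cc2)cc1`) gives 51.2% and compound 3 (`Nc1ccccc1NC(=O)/C=C/c1ccc(CSCCc2ccccc2)cc1`) gives 45.7%, so compound 3 stands within the scatter of both others. Compound 4 (`CC(C)(C)c1ccc(SCc2ccc(/C=C/C(=O)Nc3ccccc3N)cc2)cc1`) differs from it as follows: 4-(tert-butyl)phenyl in place of phenethyl on a sulfur. The bearing evidence is a number 2.3 percentage points higher from compound 1 to compound 3 (within the scatter) and a number 5.5 percentage points lower from compound 2 to compound 3 (within the scatter), both exchanges on the sulfur, plus a number 7.8 percentage points higher from compound 1 to compound 2 (within the scatter), an exchange on the aromatic carbon. Going by the values given here, no measured compound carries a 4-(tert-butyl)phenyl group, so this extrapolation is untested, and no step beyond the scatter is expected. The expected step is a number 0.7 percentage points lower from compound 3 to compound 4 (within the scatter). For compound 4 the estimated value is 45%, with an expected range of 33% to 57%.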

Compound 4, percent growth inhibition at one concentration: 71.5%
The estimate for compound 4 lay 26.5 percentage points below the measured number, outside the stated range (above it).
By their numbers in this assay, from the lowest: compounds 1, 3 and 2 (each within the scatter of the next); then compound 4.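

In this assay, going by these compounds alone, 4-(tert-butyl)phenyl on the sulfur gives the first step at this position beyond the scatter (a number 25.8 percentage points higher from compound 3 to compound 4 (beyond the scatter)). Within the data shown here, on the aromatic carbon, tert-butyl also clears the scatter in place of fluoro (a number 20.3 percentage points higher from compound 2 to compound 4 (beyond the scatter)) and in place of methyl (a number 28.1 percentage points higher from compound 1 to compound 4 (beyond the scatter)), so this position is not flat across the series as the earlier compounds suggested. No evidence bearing on the cause of these steps is available. Going by these compounds, whether an isopropyl, a cyclohexyl or a dimethylamino group on that aromatic carbon would give a similar step remains open.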